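A few compounds are considered here, and "the series" means these few. Any claim that something is new, unique, unknown or untested is made for them only; others in the source may bear on it.

Measured in an in vitro assay on Sf21 cells for inhibition of high affinity 3',5'-cyclic-AMP phosphodiesterase 7A (Homo sapiens), read by scintillation proximity assay, with a stated time of 30 min; on this read-out higher numbers stand for weaker inhibition and lower numbers for stronger inhibition:
compound 1 `Nc1ccc(NC(=O)c2cn(Cc3c(F)cccc3F)c3ccc(=O)[nH]c3c2=O)cc1`: 104 nM
compound 2 `O=C(NCc1ccncc1)c1ccc(NC(=O)c2cn(Cc3c(F)cccc3F)c3ccc(=O)[nH]c3c2=O)cc1`: 20 nM

Compound 1 stands at the highest of the two numbers; its nearest neighbour is compound 2, reached by a 5.2-fold lower number from compound 1 to compound 2 (0.72 log units; beyond the scatter) through ((pyridin-4-yl)methyl)carbamoyl in place of amino on an aromatic carbon.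

Compound 3 `O=C(Nc1ccc(C(=O)N2CCOCC2)cc1)c1cn(Cc2c(F)cccc2F)c2ccc(=O)[nH]c2c1=O` is not yet measured in this assay. It differs from compound 1 by (morpholin-4-yl)carbonyl in place of amino on an aromatic carbon. Among the compounds with values here, the one measured step that bears on this change is a 5.2-fold lower number from compound 1 to compound 2 (0.72 log units; beyond the scatter), where a carbonyl-bearing group likewise enters in place of amino on an aromatic carbon. Within the data shown here, on that basis a lowering of the number beyond the scatter is expected for compound 3, though the single precedent gives the size only roughly; the step is estimated at a 2.3-fold lower number from compound 1 to compound 3 (0.36 log units; beyond the scatter). For compound 3 the expected value in this assay is 45 nM, with a range of 15 nM to 140 nM.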

Compound 3, half-maximal inhibitory concentration: 188 nM
For compound 3 the middle estimate is 4.2-fold (0.62 log units) below the measured one, outside the stated range (above it).
By their numbers in this assay, from the lowest: compound 2; then compounds 1 and 3 (each within the scatter of the next).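

Notes on the group on the aromatic carbon para to a large group: in this assay, (morpholin-4-yl)carbonyl in place of amino gives a 1.8-fold higher number from compound 1 to compound 3 (0.26 log units; within the scatter) and so leaves compound 3 indistinguishable from compound 1, which shows that a carbonyl at this position does not by itself bring the lower number seen for compound 2. With the carbonyl held constant, morpholin-4-yl in place of ((pyridin-4-yl)methyl)amino gives a 9.4-fold higher number from compound 2 to compound 3 (0.97 log units; beyond the scatter) and thus places the difference in what the carbonyl carries. No measurement available here explains this difference.

Still open, going by these compounds, is whether the step to compound 2 depends on the pyridine ring or on the amide hydrogen. A benzylamine or a piperazine on the same carbonyl would help separate these two.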